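A few compounds are considered here, and "the series" means these few. Any claim that something is new, unique, unknown or untested is made for them only; others in the source may bear on it.

In an ADME assay on the whole organism (strain 129/SvEvBrd x C57BL/6) for metabolic stability, with Mus musculus as the target (on this read-out higher numbers stand for a longer-lived compound and lower numbers for a shorter-lived compound), compound 1 `Cc1nc(-c2nc([C@@H](O)[C@H](O)[C@H](O)CO)c[nH]2)cs1` gives 2.1 h while compound 2 `OC[C@@H](O)[C@@H](O)[C@H](O)c1c[nH]c(-c2ncc[nH]2)n1` gives 3.2 h and compound 3 `OC[C@@H](O)[C@@H](O)[C@H](O)c1c[nH]c(-c2cnccn2)n1` gives 1.9 h on the same shared core. Compound 3 thus stands within the scatter of both other compounds, so the numbers set no order among the three. The change now in question leads to compound 4 `OC[C@@H](O)[C@@H](O)[C@H](O)c1c[nH]c(-c2ncon2)n1` and consists of 1,2,4-oxadiazol-3-yl in place of pyrazin-2-yl on an aromatic carbon on an aromatic carbon of a five-membered aromatic ring with 2 nitrogen. Three measured steps exchange the group at this same place. They are a 1.5-fold higher number from compound 1 to compound 2 (0.18 log units; within the scatter) and a 1.1-fold lower number from compound 1 to compound 3 (0.04 log units; within the scatter) and a 1.7-fold lower number from compound 2 to compound 3 (0.23 log units; within the scatter) and all of them stay within the scatter, the last being the one that also removes pyrazin-2-yl. For the measured compounds named here, no measured compound carries 1,2,4-oxadiazol-3-yl, so the evidence for compound 4 is indirect. Since three different groups at this place have shown no step beyond the scatter, none is expected here in this assay either, and no direction is firmly favoured. The estimated step is only a 1.2-fold higher number from compound 3 to compound 4 (0.06 log units; within the scatter) and it remains within that scatter. For compound 4 the estimated half-life is 2.2 h with an expected range from 1.1 h to 4.2 h in this measurement.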

Compound 4, half-life: 0.7 h
The estimate for compound 4 lay 3.1-fold (0.50 log units) above the measured number; the whole stated range lies above it.
By their numbers in this assay, from the lowest: compound 4; then compounds 3, 1 and 2 (each within the scatter of the next).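

In this assay, for the compounds shown here, the place on the shared core is no longer indifferent to its group: 1,2,4-oxadiazol-3-yl is the first group there to give steps beyond the scatter, with a 2.7-fold lower number from compound 3 to compound 4 (0.43 log units; beyond the scatter) and a 3.0-fold lower number from compound 1 to compound 4 (0.48 log units; beyond the scatter) and, the largest of the three, a 4.6-fold lower number from compound 2 to compound 4 (0.66 log units; beyond the scatter) on the same read-out. The three earlier groups could not be told apart, so compound 4 is the only one that stands apart from the others, and ring size alone does not set it apart, since the 1H-imidazol-2-yl of compound 2 and the 2-methyl-1,3-thiazol-4-yl of compound 1 are five-membered aromatic rings too, while 1,2,4-oxadiazol-3-yl is the only group shown that brings in a ring oxygen. Nothing available explains why the number falls with this group.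

The compounds shown leave open whether the drop follows the ring oxygen or the whole 1,2,4-oxadiazol-3-yl group, which the isomeric 1,3,4-oxadiazol-2-yl or a methyl group on the same ring could test. They also leave open how an open-chain amine or a carboxylic acid would behave at this place.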